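This account rests on a few compounds, and the source may have more. Where it says the series, first, only, none or still open, it means among the compounds named here.

Compound 1 `Cc1cc(Cl)cc(-c2ccnc3cc(CN4C(=O)C5C(C4=O)C5(C)C)sc23)c1C[C@@H]1CNCCO1` gives 25 nM in an assay on RKO cells for inhibition of ubiquitin carboxyl-terminal hydrolase 7 (Homo sapiens), read by a luciferase reporter, with a stated time of 18 h (on this read-out lower numbers stand for an effect already at smaller amounts and higher numbers for an effect only at larger amounts of compound), the lowest of the three numbers measured. Compound 3 `Cc1cc(Cl)cc(-c2ccnc3cc(CN4C(=O)C5CC5C4=O)sc23)c1C[C@@H]1CNCCO1` gives 35 nM in this assay, and the step of a 1.4-fold higher number from compound 1 to compound 3 (0.15 log units; within the scatter) shows that swapping one imide group for another changes little. Compound 2 `Cc1cc(Cl)cc(-c2ccnc3cc(CN4C(=O)CCC4=O)sc23)c1CN1CCNC[C@@H]1C` gives 280 nM in this assay, but it differs from compound 1 in two places at once, so its higher number cannot be tied to either change alone. Compound 4 `Cc1cc(Cl)cc(-c2ccnc3cc(CN4C(=O)C5C(C4=O)C5(C)C)sc23)c1O[C@@H]1CCNC[C@@H]1C` carries the change ((3-methylpiperidin-4-yl)oxy in place of (morpholin-2-yl)methyl on an aromatic carbon). Going by the values given here, no measured step touches this part of the molecule; the one measured step concerns the imide instead. The number for compound 4 is therefore expected to stay near compound 1, with a step of a 2.4-fold higher number from compound 1 to compound 4 (0.38 log units; beyond the scatter), and an estimate of 60 nM, ranging from 15 nM to 250 nM.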

Compound 4, half-maximal effective concentration: 65 nM
Compound 4: the middle estimate sits 1.1-fold (0.03 log units) below what was measured; the measured number falls inside the stated range.
By their numbers in this assay, from the lowest: compounds 1, 3 and 4 (each within the scatter of the next, the first and the last beyond it); then compound 2.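

Going by these compounds alone, this is the first measured change at this position, on the aromatic carbon para to the chloro group. In this assay, (3-methylpiperidin-4-yl)oxy in place of (morpholin-2-yl)methyl gives a 2.6-fold higher number from compound 1 to compound 4 (0.41 log units; beyond the scatter), so the position responds to the swap, though only modestly. No available evidence explains this step. The linking atom, the ring and the methyl group all differ at once, and the step cannot be divided among them. On these data alone, how a plain piperidin-4-yloxy group without the methyl would compare remains open.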